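Swapping chloro for dimethylamino on compound 2

A few compounds are considered here, and "the series" means these few. Any claim that something is new, unique, unknown or untested is made for them only; others in the source may bear on it.

Compound 1 `O=C(Nc1ccc(NCC2CCCC2)cc1Cl)c1cc(Cl)ccc1O`: 21500 nM
Compound 2 `O=C(Nc1ccc(NCc2ccc(Cl)cc2)cc1Cl)c1cc(Cl)ccc1O`: 59700 nM
Compound 3 `CN(C)c1ccc(CNc2ccc(NC(=O)c3cc(Cl)ccc3O)c(Cl)c2)cc1`: not yet measured

In an ADME assay on A549 cells (Homo sapiens) for cytotoxicity, read by resazurin assay, with a stated time of 48 h (on this read-out higher numbers stand for lower toxicity in this test and lower numbers for higher toxicity in this test), compound 2 stands highest of the two measured compounds, at 59700 nM. Compound 3 differs from it by dimethylamino in place of chloro on an aromatic carbon. Within the data shown here, the only measured step, a 2.8-fold higher number from compound 1 to compound 2 (0.44 log units; beyond the scatter), put 4-chlorophenyl in place of cyclopentyl. It is modest and concerns a different change, so it offers only a rough guide to size. A smaller step downward is therefore expected, possibly no larger than the scatter. The expected change is a 1.7-fold lower number from compound 2 to compound 3 (0.23 log units; within the scatter). The estimate for compound 3 is 35000 nM, with an expected range of 12000 nM to 90000 nM.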

Compound 3, half-maximal cytotoxic concentration: 24500 nM
The estimate for compound 3 lay 1.4-fold (0.15 log units) above the measured number; low and high end bracket the measured number.
By their numbers in this assay, from the lowest: compounds 1 and 3 (each within the scatter of the next); then compound 2.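

In this assay, the aromatic carbon para to a large group proves able to shift the number: dimethylamino in place of chloro gives a 2.4-fold lower number from compound 2 to compound 3 (0.39 log units; beyond the scatter) and this is beyond the scatter. The ring swap seen earlier now looks tied to its substituent, since 4-(dimethylamino)phenyl in place of cyclopentyl gives a 1.1-fold higher number from compound 1 to compound 3 (0.06 log units; within the scatter) and this stays within the scatter. Nothing available explains why this substituent changes the number.

As far as these compounds go, whether the drop is specific to dimethylamino remains open. A methoxy group or a simple amino group on the same carbon could land near compound 2 or near compound 3.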